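Ethyl added to the phenoxymethyl benzamide of compound 1

A few compounds are considered here, and "the series" means these few. Any claim that something is new, unique, unknown or untested is made for them only; others in the source may bear on it.

Measured compounds:
Compound 1, `Nc1ccccc1NC(=O)c1ccc(COc2ccccc2)cc1`: in a functional assay on A549 cells (Homo sapiens) for antiproliferative activity, read by CCK-8 assay, with a stated time of 72 h (on this read-out lower numbers stand for stronger inhibition and higher numbers for weaker inhibition), compound 1 gives 6760 nM.
Compound 3, `C/C(=N\O)c1ccc(OCc2ccc(C(=O)NO)cc2)cc1`: in this assay compound 3 gives 8930 nM.
Compound 2, `Nc1cnccc1NC(=O)/C=C/c1ccc(COc2ccccc2)cc1`: in this assay compound 2 reaches only a limit of the assay, > 32000 nM.

Compound 1 holds the lowest of the two numbers shown, yet compound 3 sits so close that the gap is within the scatter, and the two cannot be ordered. Compound 2 gives only a limit, as the line the limit of > 32000 nM in this assay, at which 1 of the 3 values shown sits, records.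

Compound 4, `CCc1ccc(OCc2ccc(C(=O)Nc3ccccc3N)cc2)cc1`, is compound 1 changed in a single place: ethyl in place of hydrogen on an aromatic carbon. Going by the values given here, no measured pair shows a step of this kind, so its size must be guessed from compound 1 alone. The author expects the step from compound 1 to compound 4 in this assay to be small, at most a modest lowering of the number, and possibly none beyond the scatter, with a 1.5-fold lower number from compound 1 to compound 4 (0.18 log units; within the scatter) as the expected size. Compound 4 is therefore estimated at 4500 nM, with a range from 1500 nM to 15000 nM.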

Compound 4, half-maximal inhibitory concentration: 6420 nM
The estimate for compound 4 lay 1.4-fold (0.15 log units) below the measured number; the measured number falls inside the stated range.
By their numbers in this assay, from the lowest: compounds 4, 1 and 3 (each within the scatter of the next). At a limit, above all of these: compound 2.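

In this assay, ethyl in place of hydrogen on this aromatic carbon, para to a large group, gives a 1.1-fold lower number from compound 1 to compound 4 (0.02 log units; within the scatter). This is the first step shown at this position, and it shows that the change from phenyl to 4-ethylphenyl on the core of compound 1 leaves the read-out within the scatter. Nothing measured here points to a cause for this outcome.

On these data alone, it remains open whether this position would tolerate other groups in the same way, such as a hydroxyl, an amine, a carboxylic acid or a longer chain. As far as these compounds go, it is also open whether ethyl on another carbon of the same ring would give a number as close to that of compound 1.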